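A few compounds are considered here, and "the series" means these few. Any claim that something is new, unique, unknown or untested is made for them only; others in the source may bear on it.

Measured compounds in a functional assay, read by spectrophotometry, with a stated time of 30 min; on this read-out lower numbers stand for an effect already at smaller amounts and higher numbers for an effect only at larger amounts of compound:
Compound 1 `CCOC(=O)CC(=O)OCC1Oc2ccc([C@H]3Oc4cc(O)cc(O)c4C(=O)[C@@H]3O)cc2OC1c1ccc(O)c(OC)c1` gives 101000 nM.
Compound 2 `COc1cc(C2Oc3cc([C@H]4Oc5cc(O)cc(O)c5C(=O)[C@@H]4O)ccc3OC2COC(=O)c2cc(N)cc([N+](=O)[O-])c2)ccc1O` gives only a limit of the assay, > 300000 nM.
Compound 3 `COc1cc(C2Oc3cc([C@H]4Oc5cc(O)cc(O)c5C(=O)[C@@H]4O)ccc3OC2COC(=O)c2ccc(OC)c(OC)c2)ccc1O` gives 77000 nM.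

Compound 3 thus holds the lowest of the two numbers, with compound 1 nearest to it; the step of a 1.3-fold lower number from compound 1 to compound 3 (0.12 log units; within the scatter) lies within the scatter. The step of an at least 3.8-fold lower number from compound 2 to compound 3 (0.59 log units; beyond the scatter) is the only one beyond the scatter, and it rests on (the limit of > 300000 nM in this assay, at which 1 of the 3 values shown sits).

Compound 4 `COc1cc(C2Oc3cc([C@H]4Oc5cc(O)cc(O)c5C(=O)[C@@H]4O)ccc3OC2COC(=O)/C=C/c2ccc(Br)cc2)ccc1O` differs from compound 3 in one place: 2-(4-bromophenyl)ethenyl in place of 3,4-dimethoxyphenyl on a carbonyl carbon. Both measured steps that touch this carbonyl carbon bear on the exchange. The step of a 1.3-fold lower number from compound 1 to compound 3 (0.12 log units; within the scatter) shows that swapping one group for another there can leave the read-out unchanged, while the step of an at least 3.8-fold lower number from compound 2 to compound 3 (0.59 log units; beyond the scatter) shows that another group can push it to a limit. An aryl group is again kept in compound 4, so a step no larger than the scatter is expected in this assay, in either direction. Compound 4 is therefore estimated at 100000 nM, with a range from 40000 nM to 300000 nM. The step this estimate means, a 1.3-fold higher number from compound 3 to compound 4 (0.11 log units; within the scatter), is expected to stay within the scatter.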

Compound 4, half-maximal effective concentration: 88900 nM
Compound 4: middle estimate off by 1.1-fold (0.05 log units), on the high side, and the stated range covers the measured number.
By their numbers in this assay, from the lowest: compounds 3, 4 and 1 (each within the scatter of the next). At a limit, above all of these: compound 2.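

In this assay, a 1.2-fold higher number from compound 3 to compound 4 (0.06 log units; within the scatter) and a 1.1-fold lower number from compound 1 to compound 4 (0.06 log units; within the scatter) show that this carbonyl carbon also takes 2-(4-bromophenyl)ethenyl, with its double bond outside aromatic rings and without the hydrogen-bond acceptors of 3,4-dimethoxyphenyl, and no step beyond the scatter follows. Among the groups shown there, only 3-amino-5-nitrophenyl stands apart, with an at least 3.3-fold lower number from compound 2 to compound 4 (0.52 log units; beyond the scatter). That step gives no exact size, as the value of compound 2 is a limit: the limit of > 300000 nM in this assay, at which 1 of the 4 values shown sits.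

The compounds shown leave open whether the amino or the nitro group of 3-amino-5-nitrophenyl goes with that limit, and how a simple amine or a carboxylic acid on this carbonyl carbon would read. They also leave open whether a saturated two-carbon chain could stand in for the ethenyl link.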